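Dichlorophenyl regiochemistry in a dienone series

The compounds below may be only part of what the source reports. "The series", "measured", "known", "first", "only" and "open" are said of these compounds alone.

Of the compounds shown here, three have been measured and a fourth awaits measurement. Compound 1 `O=C(/C=C/c1ccc(Cl)c(Cl)c1)/C=C/c1ccccc1Oc1ncnc2ccc(Cl)cc12` and compound 2 `O=C(/C=C/c1ccc(Oc2ncnc3ccc(Cl)cc23)cc1)/C=C/c1ccc(Cl)c(Cl)c1` carry the same atoms joined differently; the difference between the two cores is not broken down here. Compound 3 `O=C(/C=C/c1ccc(Oc2ncnc3ccc(Cl)cc23)cc1)/C=C/c1cccc(Cl)c1Cl` shares its core with compound 2. In a functional assay on PC-3 cells (Homo sapiens) for inhibition, read by MTT assay, with a stated time of 72 h (on this read-out lower numbers stand for stronger inhibition and higher numbers for weaker inhibition), compound 1 gives 18300 nM, and compound 2 gives 18800 nM; the two values lie within the usual scatter of each other. In this assay compound 3 gives 10200 nM.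

For the measured compounds named here, the one change measured is 2,3-dichlorophenyl in place of 3,4-dichlorophenyl on a double-bonded chain carbon bound to a double-bonded chain carbon. It produced a 1.8-fold lower number from compound 2 to compound 3 (0.27 log units; within the scatter), a step that does not stand out from the scatter of repeated measurements.

Compound 4 `O=C(/C=C/c1ccccc1Oc1ncnc2ccc(Cl)cc12)/C=C/c1cccc(Cl)c1Cl` has not yet been measured. It relates to compound 1 exactly as compound 3 relates to compound 2, the change being (2,3-dichlorophenyl in place of 3,4-dichlorophenyl on a double-bonded chain carbon bound to a double-bonded chain carbon). The place lines of the two changes read the same, so this is the same change made on the core of compound 1 rather than on the core of compound 2.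

Going by the values given here, for compound 4 the step is expected to be a 1.7-fold lower number from compound 1 to compound 4 (0.22 log units; within the scatter) in this assay, a size taken from the only precedent, because the same change from compound 2 to compound 3 gave a 1.8-fold lower number from compound 2 to compound 3 (0.27 log units; within the scatter). Compound 4 is therefore estimated at 11000 nM in this assay, with a range from 5000 nM to 25000 nM to allow for a single precedent that itself sits within the scatter.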

Compound 4, half-maximal inhibitory concentration: 8350 nM
For compound 4 the middle estimate is 1.3-fold (0.12 log units) above the measured one, within the range that was stated.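

In this assay, 2,3-dichlorophenyl in place of 3,4-dichlorophenyl on the core of compound 1 gives a 2.2-fold lower number from compound 1 to compound 4 (0.34 log units; beyond the scatter), a modest step in the same direction as the one seen on the core of compound 2. The two steps do not differ, so within this pair of cores the change carries over with its direction and size intact: the same change on two cores in this assay, a 1.8-fold lower number (0.27 log units; within the scatter) from compound 2 to compound 3 and a 2.2-fold lower number (0.34 log units; beyond the scatter) from compound 1 to compound 4, 1.2-fold (0.08 log units) apart, within the scatter of two such steps. For the compounds shown here, this rests on two cores and one pair on each, and only the step on the core of compound 1 clears the scatter, so it shows agreement between these two cases and neither a general rule for the series nor any reason for the shift.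

The compounds shown leave open how other groups would behave in the same place, such as a phenyl carrying a single chlorine, a methoxy group, an amine or a carboxylic acid, and whether any of these would move the number further than the dichlorophenyl swap does. Also open, on these data alone, is whether the step would hold on a third core or in any read-out other than this assay.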